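This account rests on a few compounds, and the source may have more. Where it says the series, first, only, none or still open, it means among the compounds named here.

In a functional assay on NCI-H520 cells (Homo sapiens) for inhibition, read by MTT assay, with a stated time of 48 h, tested at 10 uM (on this read-out higher numbers stand for more inhibition at the one concentration tested (going by the name of the read-out) and lower numbers for less inhibition), compound 1 `Cc1ccc(Nc2cc(NC(=O)Nc3c(Cl)cccc3Cl)ncn2)cc1F` gives 33.5%. Compound 2 `COc1cc(NC(=O)Nc2cc(Nc3ccc(F)c(Cl)c3)ncn2)cc(OC)c1` gives 25.5% in the same test, and the two readings lie within the usual scatter of each other, so neither compound can be placed above the other on the numbers shown. Among the measured compounds shown here, no two of the measured compounds differ in a single place, so no step between measured compounds is known here. Compound 3 `COc1cc(Br)ccc1Nc1cc(NC(=O)Nc2c(Cl)cccc2Cl)ncn1` has not yet been measured. Set against compound 1, it carries 4-bromo-2-methoxyphenyl in place of 3-fluoro-4-methylphenyl on a nitrogen on an aromatic ring. For the measured compounds named here, nothing among the measured compounds shows how a change at that nitrogen affects the reading, because compound 1 gives 33.5% and compound 2 gives 25.5% after an alteration in a different part of the molecule. One would therefore expect the step of a number 3.5 percentage points lower from compound 1 to compound 3 (within the scatter) to be small, in no settled direction, and not beyond the scatter. Compound 3 is estimated at 30%, with a range from 10% to 55%.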

Compound 3, a percentage reported as inhibition, at one concentration (the size of the read-out at that concentration, not a potency): 29.1%
The estimate for compound 3 lay 0.9 percentage points above the measured number; measured number inside the range.
By their numbers in this assay, from the lowest: compounds 2, 3 and 1 (each within the scatter of the next).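

In this assay, the first step read at this position replaces 3-fluoro-4-methylphenyl with 4-bromo-2-methoxyphenyl on a nitrogen on an aromatic ring (a number 4.4 percentage points lower from compound 1 to compound 3 (within the scatter)), so this pair gives no sign that the change separates the two compounds. The exchange alters the substituents on the ring, with fluorine and methyl giving way to bromine and methoxy, and the entering group carries a hydrogen-bond acceptor where the leaving group carries none, yet the six-membered aromatic ring of carbon stays on the nitrogen and the reading remains within the scatter. Nothing available gives a measured property that bears on this result or accounts for it.

The compounds shown leave open what bromine and methoxy each contribute, since both arrive in a single step and a compensating pair of effects cannot be told from two changes that do nothing. They also leave open whether a group of a different kind on that nitrogen, such as a phenyl ring bearing a carboxylic acid or a basic amine on a longer chain, would move the reading beyond the scatter.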